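Aryl exchange on compound 2: expected efficacy of compound 4

The source may hold more compounds than are shown below. What is called first, only, known or untested is meant among the compounds shown, and "the series" means these compounds.

Working notes on the series. Compound 1 `O=C(O)Cc1sc(C(c2ccccc2)c2ccccc2)nc1-c1ccc(F)cc1` gives 80% in an in vitro functional assay on HEK285-7 cells for antagonist activity at prostaglandin D2 receptor 2 (Homo sapiens), read by BRET and beta-arrestin recruitment; on this read-out higher numbers stand for larger maximal responses and lower numbers for smaller maximal responses. Compound 2 `O=C(O)Cc1sc(C(c2ccc(F)cc2)c2ccc(F)cc2)nc1-c1cccc(F)c1` gives 80% in this assay, level with compound 1 within the usual scatter, and these two together stand highest of the three numbers measured. Compound 3 `O=C(O)Cc1sc(NCc2ccccc2)nc1-c1ccc(Cl)cc1` gives 30% in this assay, a reading well below compound 2 and beyond the scatter. Going by the values given here, no pair of measured compounds differs in a single place, so the size of the step to compound 4 `O=C(O)Cc1sc(C(c2ccc(F)cc2)c2ccc(F)cc2)nc1-c1ccnc(N2CCC2)c1` cannot be read from a measured pair. Compound 4 differs from compound 2 in one place: 2-(azetidin-1-yl)pyridin-4-yl in place of 3-fluorophenyl on an aromatic carbon. The remainder of compound 2 is kept unchanged.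

Since compounds 1 and 2 show the same efficacy although their aromatic substituents differ, only a small step in this assay, if any, is expected, with a slight downward lean for the larger entering group; the expected step is a number 10 percentage points lower from compound 2 to compound 4 (within the scatter). Compound 4 is therefore expected to give 70% in this assay, with an estimated range from 45% to 95%.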

Compound 4, largest response reached (reported as efficacy), in percent of the reference or control that the assay uses: 80%
Compound 4: the middle estimate sits 10 percentage points below what was measured, within the range that was stated.
By their numbers in this assay, from the lowest: compound 3; then compounds 1, 2 and 4 (each within the scatter of the next).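

In this assay, going by these compounds alone, putting 2-(azetidin-1-yl)pyridin-4-yl in place of 3-fluorophenyl gives no change at the digits printed from compound 2 to compound 4 (within the scatter), the only step that can be read at this position. On this aromatic carbon next to the ring nitrogen, the maximal response therefore holds through a change to 10 heavy atoms from 7, to 2 hydrogen-bond acceptors from 0, and to an added four-membered non-aromatic ring. Nothing available explains why the response holds through this exchange.

Steps between the other compounds cannot be read, as those pairs differ in more than one place. Still open, from the compounds shown here alone, is whether the same holds for an unsubstituted pyridin-4-yl, which would separate the azetidine from the pyridine part of the entering group, or for a primary amine or carboxylic acid on that ring.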